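From benzyl to cyclohexyl on the shared core

A few compounds are considered here, and "the series" means these few. Any claim that something is new, unique, unknown or untested is made for them only; others in the source may bear on it.

In a functional assay on a cell-free system (Platelet, plasma, Homo sapiens) for inhibition, with stated times of 1 min and 3 min (on this read-out lower numbers stand for stronger inhibition and higher numbers for weaker inhibition), compound 1 `CC(C)Sc1nc(NC2CCCCC2)c2ncn([C@@H]3O[C@H](CO)[C@@H](O)[C@H]3O)c2n1` gives 187000 nM and compound 2 `CCCCSc1nc(NCc2ccccc2)c2ncn([C@@H]3O[C@H](CO)[C@@H](O)[C@H]3O)c2n1` gives 202000 nM on the same scale. Compound 2 therefore stands within the scatter of compound 1, and the two numbers cannot be told apart. Both sit high on this read-out, which marks weak inhibition.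

Compound 3 `CCCCSc1nc(NC2CCCCC2)c2ncn([C@@H]3O[C@H](CO)[C@@H](O)[C@H]3O)c2n1` departs from compound 2 in one place, with cyclohexyl in place of benzyl on a nitrogen on an aromatic ring is the whole difference. Among the measured compounds shown here, no two measured compounds differ in one place alone, so the data offer no direct measure of this change. The expected outcome in this assay is no step beyond the scatter in either direction, and the estimate means a 1.1-fold lower number from compound 2 to compound 3 (0.03 log units; within the scatter) for this change. Compound 3 is estimated at 190000 nM with an expected range from 100000 nM to 350000 nM for this value.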

Compound 3, half-maximal inhibitory concentration: 83000 nM
Compound 3: middle estimate off by 2.3-fold (0.36 log units), on the high side; the measured number lies below the stated range.
By their numbers in this assay, from the lowest: compound 3; then compounds 1 and 2 (each within the scatter of the next).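

In this assay the swap of benzyl for cyclohexyl on a nitrogen on an aromatic ring gives a 2.4-fold lower number from compound 2 to compound 3 (0.39 log units; beyond the scatter) with butyl held on the sulfur, so this position responds to the change when it is taken alone, which the earlier pair, differing in two places, could not show. The sulfur also responds: butyl in place of isopropyl gives a 2.3-fold lower number from compound 1 to compound 3 (0.35 log units; beyond the scatter) with cyclohexyl held on the nitrogen, and both steps are modest. Nothing measured here bears on why either step occurs.

Going by these compounds, whether the lower number follows from the saturated ring as such or from the departure of the benzyl group stays open. How a cyclopentyl or phenyl group on this nitrogen, or a hexyl chain on the sulfur, would read on this scale also remains an open question.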